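This account rests on a few compounds, and the source may have more. Where it says the series, first, only, none or still open, it means among the compounds named here.

Measured compounds:
compound 1, `C=C/C=C\[C@H](C)[C@H](OC(N)=O)[C@@H](C)[C@H](O)[C@@H](C)C/C(C)=C\[C@H](C)[C@@H](O)[C@@H](C)/C=C\CCc1ccccc1`, 510 nM;
compound 2, `C=C/C=C\[C@H](C)[C@H](OC(N)=O)[C@@H](C)[C@H](O)[C@@H](C)C/C(C)=C\[C@H](C)[C@@H](O)[C@@H](C)/C=C\CCc1ccsc1`, 4000 nM;
compound 3, `C=C/C=C\[C@H](C)[C@H](OC(N)=O)[C@@H](C)[C@H](O)[C@@H](C)C/C(C)=C\[C@H](C)[C@@H](O)[C@@H](C)/C=C\CCc1ccc(Oc2ccccc2)cc1`, 10000 nM.

These three share one core and differ only in the aromatic group at the far end of the chain. In a functional assay on A549 cells (Homo sapiens) for cytotoxicity (a lower number here means a stronger inhibitor, a higher number a weaker inhibitor), compound 2 stands second highest of the three numbers: compound 3 sits nearer to it, with a higher number, while compound 1 lies further off with a lower number. Compound 4, `C=C/C=C\[C@H](C)[C@H](OC(N)=O)[C@@H](C)[C@H](O)[C@@H](C)C/C(C)=C\[C@H](C)[C@@H](O)[C@@H](C)/C=C\CCc1cccc(OC)c1`, has not been measured. It differs from compound 2 in one place: 3-methoxyphenyl in place of thiophen-3-yl on a saturated chain carbon, two bonds along the chain from a double-bonded chain carbon.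

Going by the values given here, two measured steps bear on this change. The step of a 7.8-fold higher number from compound 1 to compound 2 (0.89 log units; beyond the scatter) shows that the thiophen-3-yl group carried a weaker result than phenyl, so returning to a six-membered carbon ring points toward a lower number. The step of a 20-fold higher number from compound 1 to compound 3 (1.29 log units; beyond the scatter), however, shows that adding a substituent on the aromatic ring raised the number strongly. A methoxy group is a smaller addition than phenoxy, so the two pulls are expected to partly cancel, leaving compound 4 somewhere between compound 1 and compound 2, with a modest downward step a 2.7-fold lower number from compound 2 to compound 4 (0.43 log units; beyond the scatter) expected in this assay.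

Compound 4 is therefore estimated at 1500 nM, with a range of 500 nM to 5000 nM.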

Compound 4, half-maximal inhibitory concentration: 600 nM
Compound 4: middle estimate off by 2.5-fold (0.40 log units), on the high side; the measured number falls inside the stated range.
By their numbers in this assay, from the lowest: compounds 1 and 4 (each within the scatter of the next); then compound 2; then compound 3.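

At this end of the chain, 3-methoxyphenyl in place of thiophen-3-yl gives a 6.7-fold lower number from compound 2 to compound 4 (0.82 log units; beyond the scatter) in this assay, a step that reaches back to the level of the unsubstituted phenyl compound. The added methoxy group gives only a 1.2-fold higher number from compound 1 to compound 4 (0.07 log units; within the scatter), so compound 1 and compound 4 cannot be told apart here, whereas the earlier step of a 20-fold higher number from compound 1 to compound 3 (1.29 log units; beyond the scatter) had shown only a phenoxy group on the ring, with a much higher number; compound 3 therefore stands against any rule that a six-membered carbon ring at this place keeps the number low, and a substituent on that ring does not always raise it. No measurement shown here explains why these groups differ.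

The compounds shown leave open whether a small group of another kind on the ring, such as an amine or a carboxylic acid in place of the methoxy group, would stay level with compound 1 or move as far as compound 3. They also leave open how a longer chain between the double bond and the 3-methoxyphenyl ring would read in this cell assay.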